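The source may report more compounds than this note shows. Statements on the series, on what has been measured and on what is new or still open speak of the compounds shown alone.

Measured compounds:
Compound 1, `N#CC1CN1C(=O)NCc1ccccc1`: 11000 nM
Compound 2, `N#CC1CN1C(=O)Nc1ccc(S(N)(=O)=O)cc1`: 188000 nM

Both were tested in a functional assay on A-375 cells (Homo sapiens) for inhibition; a higher number here means a weaker inhibitor, a lower number a stronger inhibitor. Compound 2 stands at the higher of the two numbers, and compound 1 sits well below it, a gap wider than the usual scatter of repeat measurements. Compound 3, `N#CC1CN1C(=O)Nc1ccc(F)cc1`, is not yet measured. It differs from compound 2 in one place: fluoro in place of sulfamoyl on an aromatic carbon. Among the compounds with values here, no pair of measured compounds isolates this change, so there is no direct guide to its effect. A moderate move toward a lower number is expected, a 3.8-fold lower number from compound 2 to compound 3 (0.58 log units; beyond the scatter), with wide uncertainty. For compound 3 the estimated result in this assay is 50000 nM, within 10000 nM to 200000 nM.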

Compound 3, half-maximal inhibitory concentration: 3400 nM
Estimate against measurement, compound 3: 15-fold (1.17 log units) above; the measured number lies below the stated range.
By their numbers in this assay, from the lowest: compound 3; then compound 1; then compound 2.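

The group on this aromatic carbon has a large influence on the result: in this assay, fluoro in place of sulfamoyl gives a 55-fold lower number from compound 2 to compound 3 (1.74 log units; beyond the scatter). Sulfamoyl is therefore not needed here for inhibition, and the much smaller fluoro gives the stronger inhibitor of this pair. Nothing measured here bears on the reason for this step.

As far as these compounds go, it remains open whether the gain comes from fluoro itself or simply from losing sulfamoyl, and a plain hydrogen on this carbon would separate the two. From the compounds shown here alone, how chloro, methoxy or an amine would compare at this place also remains open.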